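This account rests on a few compounds, and the source may have more. Where it says the series, first, only, none or still open, it means among the compounds named here.

Measured compounds, in a functional assay on EC17 cells (Homo sapiens) for inhibition, with a stated time of 24 h; a lower number here means a stronger inhibitor, a higher number a weaker inhibitor:
- compound 1 `C=C(CC[C@H]1[C@@H](C)CCCC1(C)C)C(O)Cc1c(O)cc(C)c(C=O)c1O` gives 1980 nM
- compound 2 `C=C(CCC1CCCCC1)C(O)Cc1c(O)cc(C)c(C=O)c1O` gives 8430 nM
- compound 3 `C=C(C)C(O)Cc1c(O)cc(C)c(C=O)c1O` gives 30000 nM

Compound 2 holds the second highest number of the three in this assay: compound 3 sits above it and compound 1 below it, both gaps beyond the scatter.

Compound 4 `C=C(CC/C=C(\C)CCC=C(C)C)C(O)Cc1c(O)cc(C)c(C=O)c1O` is not yet measured. Against compound 2 the change is 2,6-dimethylhepta-1,5-dien-1-yl in place of cyclohexyl on a saturated chain carbon, two bonds along the chain from a double-bonded chain carbon.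

Going by the values given here, two measured steps bear on this place in the chain. a 4.3-fold higher number from compound 1 to compound 2 (0.63 log units; beyond the scatter) shows that trimming the substituted ring to a bare cyclohexyl raises the number; a 3.6-fold higher number from compound 2 to compound 3 (0.55 log units; beyond the scatter) shows that removing the ring altogether raises it further. Both point the same way: more carbon at this position goes with a lower number in this assay. Among the compounds with values here, the entering group in compound 4 carries more carbon than cyclohexyl, though as an open chain rather than a ring, and no measured pair tests an open chain here. A modest lowering is therefore expected, a 3.4-fold lower number from compound 2 to compound 4 (0.53 log units; beyond the scatter), with wide uncertainty.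

Estimate for compound 4 in this assay: 2500 nM, range 800 nM to 8000 nM.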

Compound 4, half-maximal inhibitory concentration: 7530 nM
Estimate against measurement, compound 4: 3.0-fold (0.48 log units) below; low and high end bracket the measured number.
By their numbers in this assay, from the lowest: compound 1; then compounds 4 and 2 (each within the scatter of the next); then compound 3.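

In this assay, a 1.1-fold lower number from compound 2 to compound 4 (0.05 log units; within the scatter) shows that the open 2,6-dimethylhepta-1,5-dien-1-yl chain, with 9 heavy atoms, is not separated from the cyclohexyl ring with 6, so the link between more carbon and a lower number seen across compounds 1, 2 and 3 does not extend to compound 4. With a 3.8-fold higher number from compound 1 to compound 4 (0.58 log units; beyond the scatter), the open chain also stays apart from the 2,2,6-trimethylcyclohexyl group, so at this place on the chain the identity of the group counts for more than its carbon alone. No supporting evidence accounts for these differences.

On these data alone, whether the double bonds or the methyl branches of the open chain affect the number remains open. A saturated chain, a phenyl ring or a terminal amine at this place would test how far the series tolerates other groups.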